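Ethyl in place of phenyl on the chain of compound 3

This account rests on a few compounds, and the source may have more. Where it says the series, first, only, none or still open, it means among the compounds named here.

Measured compounds and their values:
compound 1 `Cc1ccccc1CNC(=O)n1c(N)nc2ccccc21`: 68.4 nM
compound 2 `CCCCCCNC(=O)n1cnc2ccccc21`: 6.6 nM
compound 3 `Nc1nc2ccccc2n1C(=O)NCCCCc1ccccc1`: 0.9 nM

In an assay on HEK293 cells for inhibition of acid ceramidase (Homo sapiens), read by fluorescence, with stated times of 30 min and 1 h (on this read-out lower numbers stand for stronger inhibition and higher numbers for weaker inhibition), compound 3 gives 0.9 nM, the lowest of the three numbers. Its nearest neighbour is compound 2, whose value in this assay is higher by a margin beyond the scatter, and the furthest is compound 1, whose value is higher still, again well beyond the scatter. Compound 3 therefore stands as the strongest inhibitor among the measured three.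

Compound 4 `CCCCCCNC(=O)n1c(N)nc2ccccc21` is not yet measured. It differs from compound 3 in one place: ethyl in place of phenyl on a saturated chain carbon, four bonds along the chain from an amide-type nitrogen. The rest of the molecule, including the amino-bearing core, is unchanged.

Within the data shown here, no measured pair in this set isolates this change, so the expectation rests on the overall picture. Compound 4 shares its hexyl chain with compound 2, which lacks the amino group on the core; in this assay compound 2 gives 6.6 nM. Compound 3, with the amino group and the phenyl-ended chain, gives 0.9 nM. The step from compound 3 to compound 4 is expected to be a modest loss, a 3.3-fold higher number from compound 3 to compound 4 (0.52 log units; beyond the scatter), probably beyond the scatter but not large. Compound 4 is estimated at 3 nM, within a range of 0.8 nM to 12 nM.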

Compound 4, half-maximal inhibitory concentration: 2.4 nM
Beside the measured number, compound 4's estimate is 1.3-fold (0.10 log units) above it; measured number inside the range.
By their numbers in this assay, from the lowest: compound 3; then compound 4; then compound 2; then compound 1.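

In this assay, the phenyl at the end of the chain of compound 3 turns out not to be needed for a low number: ethyl in its place gives a 2.7-fold higher number from compound 3 to compound 4 (0.43 log units; beyond the scatter) and so costs only a modest step, with inhibition staying strong without the ring. Among these compounds, with the hexyl chain held constant, amino in place of hydrogen on an aromatic carbon gives a 2.8-fold lower number from compound 2 to compound 4 (0.44 log units; beyond the scatter) as a modest gain, which is the first direct reading of what this group on the shared core contributes. Closer to the amide-type nitrogen the change matters far more, since pentyl in place of 2-methylphenyl on the saturated chain carbon bound to that nitrogen gives a 29-fold lower number from compound 1 to compound 4 (1.45 log units; beyond the scatter) and is a large step.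

No measurement offered here explains any of these steps. Whether a longer chain, or an amine or a carboxylic acid at the end of the chain, would keep numbers this low remains open among the compounds shown, as does the effect of a phenyl on a shorter chain.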